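Swapping an aryl group on a fused core: MCF7 inhibition

A few compounds are considered here, and "the series" means these few. Any claim that something is new, unique, unknown or untested is made for them only; others in the source may bear on it.

Measured compounds:
compound 1, `O=C(Nc1ccc(Oc2ccnc3[nH]ccc23)cc1)c1cn(-c2ccc(F)c(Cl)c2)c2ccccc2c1=O`, 1510 nM
compound 2, `COc1ccc(-n2cc(C(=O)Nc3ccc(Oc4ccnc5[nH]ccc45)cc3)c(=O)c3ccccc32)cc1`, 4650 nM
compound 3, `O=C(Nc1ccc(Oc2ccnc3[nH]ccc23)c(F)c1)c1cn(-c2ccc(F)c(Cl)c2)c2ccccc2c1=O`, "not determined" (no result reported)

In a functional assay on MCF7 cells (Homo sapiens) for inhibition, read by MTT assay, with a stated time of 72 h (a higher number here means a weaker inhibitor, a lower number a stronger inhibitor), compound 1 gives 1510 nM. Compound 2 carries the change (4-methoxyphenyl in place of 3-chloro-4-fluorophenyl on an aromatic nitrogen), and in this assay compound 2 gives 4650 nM; the step is a 3.1-fold higher number from compound 1 to compound 2 (0.49 log units; beyond the scatter). Compound 3 differs from compound 1 by fluoro in place of hydrogen on an aromatic carbon, but in this assay compound 3 stands at "not determined" (no result reported), so no number is available for it. Compound 4, `COc1ccc(-n2cc(C(=O)Nc3ccc(Oc4ccnc5[nH]ccc45)c(F)c3)c(=O)c3ccccc32)cc1`, is not yet measured; it differs from compound 3 by 4-methoxyphenyl in place of 3-chloro-4-fluorophenyl on an aromatic nitrogen, the same change that separates compound 1 from compound 2. For compound 4 the weakening seen as a 3.1-fold higher number from compound 1 to compound 2 (0.49 log units; beyond the scatter) is expected to carry over, with no measured anchor in compound 3 to set its level. In this assay compound 4 is expected to give about 4500 nM, between 1500 nM and 14000 nM.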

Compound 4, half-maximal inhibitory concentration: 6620 nM
For compound 4 the middle estimate is 1.5-fold (0.17 log units) below the measured one, within the range that was stated.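

In this assay, fluoro in place of hydrogen on an aromatic carbon gives a 1.4-fold higher number from compound 2 to compound 4 (0.15 log units; within the scatter), so with 4-methoxyphenyl on the aromatic nitrogen, the two cores cannot be told apart in this assay. The steps involving compound 3 cannot be read, so this does not show whether 4-methoxyphenyl in place of 3-chloro-4-fluorophenyl has the same effect on the core of compound 3 as a 3.1-fold higher number from compound 1 to compound 2 (0.49 log units; beyond the scatter) on the core of compound 1. Nothing measured here accounts for this result.

Going by these compounds, it remains open how the two cores would compare with other groups on the aromatic nitrogen, such as a phenyl ring carrying a carboxylic acid or a dimethylamino group.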